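Swapping 2-methoxyphenyl for 4-cyanophenyl on the shared core

This account rests on a few compounds, and the source may have more. Where it says the series, first, only, none or still open, it means among the compounds named here.

In a toxicity assay on MT4 cells (Homo sapiens) for cytotoxicity, read by MTT assay (a lower number here means that less compound is tolerated, a higher number that more compound is tolerated), compound 1 (`Cc1cc(-c2ccccc2Cl)cc(C)c1Oc1cc(N)nc(Nc2ccc(C#N)cc2)n1`) gives 25100 nM, compound 2 (`Cc1cccc(-c2cc(C)c(Oc3cc(N)nc(Nc4ccc(C#N)cc4)n3)c(C)c2)c1`) gives 27600 nM and compound 3 (`COc1ccccc1-c1cc(C)c(Oc2cc(N)nc(Nc3ccc(C#N)cc3)n2)c(C)c1`) gives 21800 nM. Compound 3 therefore stands level with the other two, as a 1.2-fold lower number from compound 1 to compound 3 (0.06 log units; within the scatter) and a 1.3-fold lower number from compound 2 to compound 3 (0.10 log units; within the scatter) show.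

Compound 4 (`Cc1cc(-c2ccc(C#N)cc2)cc(C)c1Oc1cc(N)nc(Nc2ccc(C#N)cc2)n1`) has not yet been measured. It differs from compound 3 in a single group: 4-cyanophenyl in place of 2-methoxyphenyl on an aromatic carbon. In words, this is 4-cyanophenyl in place of 2-methoxyphenyl on an aromatic carbon.

The three measured steps all exchange the group at this same place, so they bear directly on the change. Besides the two steps already given, there is a 1.1-fold higher number from compound 1 to compound 2 (0.04 log units; within the scatter). Each of the three lies within the scatter, so the three groups tried so far do not separate in this assay. Among the measured compounds shown here, no measured compound carries 4-cyanophenyl at this place, however, so the new group remains untested and the range must stay wide.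

On this evidence, no step beyond the scatter is expected, in either direction. The expected change is a 1.0-fold lower number from compound 3 to compound 4 (0.02 log units; within the scatter). For compound 4 the estimated value is 21000 nM, with an expected range from 9000 nM to 38000 nM.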

Compound 4, half-maximal cytotoxic concentration: 18100 nM
For compound 4 the middle estimate is 1.2-fold (0.06 log units) above the measured one; the range from low to high includes it.
By their numbers in this assay, from the lowest: compounds 4, 3, 1 and 2 (each within the scatter of the next).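

In this assay, 4-cyanophenyl, the only group at this place among these compounds to carry a nitrile, gives a result that does not stand apart from the other three groups: the change to it reads a 1.2-fold lower number from compound 3 to compound 4 (0.08 log units; within the scatter) from 2-methoxyphenyl, a 1.4-fold lower number from compound 1 to compound 4 (0.14 log units; within the scatter) from 2-chlorophenyl and a 1.5-fold lower number from compound 2 to compound 4 (0.18 log units; within the scatter) from 3-methylphenyl. The earlier compounds had only shown that three groups at this place could not be told apart; compound 4 adds a group with a triple bond outside aromatic rings, and even the largest of these new steps stays within the scatter, so all four compounds remain level in this read-out. Nothing available on these compounds bears on why the numbers stay level at this position.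

The compounds shown leave open whether a group at this place without an aromatic ring, such as a morpholine, a simple amine or a carboxylic acid, would move the number beyond the scatter. They also leave open whether 2-cyanophenyl or 3-cyanophenyl would stay as level with these four compounds as 4-cyanophenyl does.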